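This account rests on a few compounds, and the source may have more. Where it says the series, first, only, none or still open, it means among the compounds named here.

Compound 1 `C=C1CC[C@@H]2[C@](C)(CO)[C@H](O)CC[C@@]2(C)[C@@H]1C/C=C1\C=COC1=O` is the starting point. In a physicochemical assay for lipophilicity (on this read-out lower numbers stand for lower lipophilicity and higher numbers for higher lipophilicity), compound 1 gives 3.28, the lowest of the three numbers measured. For the measured compounds named here, compound 2 `C=C1CC[C@@H]2[C@](C)(COC(C)=O)[C@H](OC(C)=O)CC[C@@]2(C)[C@@H]1/C=C/C1=CCOC1=O` gives 3.83 and compound 3 `C=C1CC[C@@H]2[C@](C)(COC(C)=O)[C@H](OC(C)=O)CC[C@@]2(C)[C@@H]1CCC1=CCOC1=O` gives 4.02; the only single-point step among them, a number 0.19 log units higher from compound 2 to compound 3 (within the scatter), removes a double bond and stays within the scatter. Compound 4 `C=C1CC[C@@H]2[C@](C)(CO)[C@H](O)CC[C@@]2(C)[C@@H]1CCC1C(=O)OC[C@H]1O` differs from compound 1 by a group of 8 heavy atoms (5 carbon, 3 oxygen; one five-membered non-aromatic ring with 1 hetero atom) in place of a group of 7 heavy atoms (5 carbon, 2 oxygen; one five-membered non-aromatic ring with 1 hetero atom), on a saturated chain carbon bound to a saturated ring carbon. Going by the values given here, that change removes two double bonds outside aromatic rings and adds one hydrogen-bond donor and one acceptor, for which no measured step gives direct guidance; the step from compound 2 to compound 3 shows only that losing a double bond alone stayed within the scatter. A fall beyond the scatter is nonetheless expected. For compound 4 the estimate is 2.3, with a range from 1.6 to 3, an expected step of a number 0.98 log units lower from compound 1 to compound 4 (beyond the scatter).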

Compound 4, partition coefficient: 2.54
Compound 4: middle estimate off by 0.24 log units, on the low side, and the stated range covers the measured number.
By their numbers in this assay, from the lowest: compound 4; then compound 1; then compounds 2 and 3 (each within the scatter of the next).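

Replacing the group in compound 1 with (4-hydroxy-2-oxooxolan-3-yl)methyl, on a saturated chain carbon bound to a saturated ring carbon, gives in this assay a number 0.74 log units lower from compound 1 to compound 4 (beyond the scatter). This is the first step shown between compounds differing in one place that goes beyond the scatter, so a change at this place can move the read-out measurably. Nothing available explains the shift or divides it among the parts of the change. Still open, on these data alone, is how much goes with the hydroxyl and how much with the lost double bonds. An amine or a carboxylic acid at this place also remains to be compared.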